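A few compounds are considered here, and "the series" means these few. Any claim that something is new, unique, unknown or untested is made for them only; others in the source may bear on it.

Of the compounds shown here, three have been measured in an ADME assay on microsomes from liver (Mus musculus) for metabolic stability, using NADPH, with a stated time of 10 min (on this read-out lower numbers stand for a less stable compound and higher numbers for a more stable compound), so far.

Compound 1 `CN(C[C@H]1Cc2ncccc2CN1)[C@H]1CCCc2cccnc21` gives 53%
Compound 2 `CN(C)CCCCN(C[C@H]1Cc2ncccc2CN1)[C@H]1CCCc2cccnc21` gives 55%
Compound 3 `CCN(CC)CCCCN(C[C@H]1Cc2ncccc2CN1)[C@H]1CCCc2cccnc21` gives 1%

Compound 3 stands lowest of the three with 1% and lies clearly under both others. Compound 4 `c1cnc2c(c1)CN[C@@H](CN(CCCCNC1CCOCC1)[C@H]1CCCc3cccnc31)C2` has not been measured yet. It differs from compound 3 in one place, with (oxan-4-yl)amino in place of diethylamino on a saturated chain carbon, four bonds along the chain from an amine nitrogen.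

Within the data shown here, three steps bear on this. Swapping dimethylamino for diethylamino at that same place gave a number 54 percentage points lower from compound 2 to compound 3 (beyond the scatter) and is the closest guide. Adding the 3-(dimethylamino)propyl group to the core gave a number 2 percentage points higher from compound 1 to compound 2 (within the scatter) while adding 3-(diethylamino)propyl gave a number 52 percentage points lower from compound 1 to compound 3 (beyond the scatter) in the same test.

From the compounds shown here alone, compound 2 holds 55% without diethylamino, so a large rise is expected, though (oxan-4-yl)amino itself is untested. The expected move is a number 39 percentage points higher from compound 3 to compound 4 (beyond the scatter) and it would lie beyond the scatter. Compound 4 is estimated at 40% (10% to 70%).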

Compound 4, percent of the compound remaining: 35%
Estimate against measurement, compound 4: 5 percentage points above, within the range that was stated.
By their numbers in this assay, from the lowest: compound 3; then compound 4; then compounds 1 and 2 (each within the scatter of the next).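

In this assay, the group at the end of the chain need not cost as much as diethylamino did: (oxan-4-yl)amino, although it has more heavy atoms, gives a number 34 percentage points higher from compound 3 to compound 4 (beyond the scatter). Size alone therefore does not set the order at this place, yet the new group does not reach the earlier compounds, with a number 20 percentage points lower from compound 2 to compound 4 (beyond the scatter) against dimethylamino and a number 18 percentage points lower from compound 1 to compound 4 (beyond the scatter) against the core without the chain. No measurement shown here explains these differences.

From the compounds shown here alone, it remains open whether the ring or its oxygen accounts for the result, which cyclohexylamino, with carbon in place of that oxygen, could help to separate. Going by these compounds, it is also open whether (oxan-4-yl)amino would behave the same way on a shorter chain, such as 2-((oxan-4-yl)amino)ethyl.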